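Swapping the Octyl Chain for a Butylphenyl Arm

A few compounds are considered here, and "the series" means these few. Any claim that something is new, unique, unknown or untested is made for them only; others in the source may bear on it.

Compound 1 `CCCCCCCCC#Cc1cn(C/C=C\CN2C(=O)c3ccccc3C2=O)c(=O)[nH]c1=O`: 67000 nM
Compound 2 `CCCCCCCCC#Cc1cn(C/C=C/CN2C(=O)c3ccccc3C2=O)c(=O)[nH]c1=O`: 87000 nM
Compound 3 `CCCCC#Cc1cn(C/C=C/CN2C(=O)c3ccccc3C2=O)c(=O)[nH]c1=O`: > 100000 nM, which is a limit of the assay and not a number.

The values come from a functional assay on SW-620 cells (Homo sapiens) for antiproliferative activity, read by MTT assay, with a stated time of 3 days; a lower number here means a stronger inhibitor, a higher number a weaker inhibitor. Compound 1 holds the lower of the two numbers, but the step of a 1.3-fold higher number from compound 1 to compound 2 (0.11 log units; within the scatter) is small, so compounds 1 and 2 cannot be told apart. Compound 3 sits at the limit of > 100000 nM in this assay, at which 1 of the 3 values shown sits.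

Compound 4 `CCCCc1ccc(C#Cc2cn(C/C=C\CN3C(=O)c4ccccc4C3=O)c(=O)[nH]c2=O)cc1` takes the step (4-butylphenyl in place of octyl on a triple-bonded carbon). Two measured steps are available for comparison, and neither matches this change. The step of a 1.3-fold higher number from compound 1 to compound 2 (0.11 log units; within the scatter) rests on the fact that compounds 1 and 2 differ only in the configuration as drawn and leaves the number where it was. From the compounds shown here alone, the step of an at least 1.1-fold higher number from compound 2 to compound 3 (0.06 log units; that floor lies within the scatter) removes part of the chain and reaches only the assay limit, so its true size is unknown. For the measured compounds named here, both steps leave the part replaced here either untouched or merely shortened; exchanging a chain for an aromatic ring has no measured precedent in this set. The expectation for this assay is therefore a step of a 1.0-fold higher number from compound 1 to compound 4 (0.02 log units; within the scatter), with wide uncertainty. Compound 4 is estimated at 70000 nM, within 20000 nM to 200000 nM.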

Compound 4, half-maximal inhibitory concentration: > 100000 nM
Compound 4: only a limit was reported (the forecaster's own chance of this, stated with the estimate: 30%); middle value at least 1.4-fold (0.15 log units) from the limit.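

In this assay compound 4 gives > 100000 nM, which is a limit of the assay and not a number. From the compounds shown here alone, exchanging octyl for 4-butylphenyl on this triple-bonded carbon brings in a six-membered aromatic ring and gives an at least 1.4-fold higher number from compound 1 to compound 4 (0.17 log units; that floor lies within the scatter), so the true size of the change is unknown and compound 4 cannot be called weaker than compound 1. The new information is that placing this aromatic arm at this position gives no measured improvement, and one more compound now sits at the edge of what the assay can report: the limit of > 100000 nM in this assay, at which 2 of the 4 values shown sit.

The compounds shown leave open whether any group on this triple-bonded carbon can shift the number clearly beyond the scatter, and whether the double bond drawn E would matter with 4-butylphenyl in place. Going by these compounds, it also remains open whether a plain phenyl ring without the butyl chain, or a phenyl ring carrying an amine or a carboxylic acid, would give a number and not a limit.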